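Two Nucleosides at the Limit, and a Larger Aryl Group

The compounds below may be only part of what the source reports. "The series", "measured", "known", "first", "only" and "open" are said of these compounds alone.

Measured in an ADME assay on MRC5 cells (Homo sapiens), read by MTT assay, with a stated time of 72 h; on this read-out lower numbers stand for stronger inhibition and higher numbers for weaker inhibition:
Compound 1 `CSc1ncnc2c1c(-c1ccoc1)cn2[C@@H]1O[C@H](CO)[C@@H](O)[C@H]1O`: > 100000 nM
Compound 2 `Nc1nc(N)c2c(-c3cccs3)cn([C@@H]3O[C@H](CO)[C@@H](O)[C@H]3O)c2n1`: > 100000 nM

Compound 2 has no exact number: its reading of > 100000 nM is a limit of the assay. Both measured compounds stand at the same place, (the limit of > 100000 nM in this assay, at which 2 of the 2 values shown sit). They differ in more than one position, so no single change can be read from them.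

Compound 3 `Nc1nc(N)c2c(-c3cc4ccccc4o3)cn([C@@H]3O[C@H](CO)[C@@H](O)[C@H]3O)c2n1` keeps the core of compound 2 but carries 1-benzofuran-2-yl in place of thiophen-2-yl on an aromatic carbon. Going by the values given here, no measured step shows what such an exchange does. In this assay little change is expected, and any shift is expected towards stronger inhibition, with a further limit quite possible. The expected size is an at least 1.4-fold lower number from compound 2 to compound 3 (0.15 log units; that floor lies within the scatter). For compound 3 the estimate is 70000 nM, with an expected range of 20000 nM to 100000 nM.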

Compound 3, half-maximal inhibitory concentration: 78500 nM
For compound 3 the middle estimate is 1.1-fold (0.05 log units) below the measured one; low and high end bracket the measured number.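

Going by these compounds alone, compound 3 gives the first exact number, with 78500 nM in this assay, so this aromatic carbon can carry 1-benzofuran-2-yl and the reading still falls inside the measurable range. Placing 1-benzofuran-2-yl there in place of thiophen-2-yl gives an at least 1.2-fold lower number from compound 2 to compound 3 (0.10 log units; that floor lies within the scatter), and that floor alone does not establish a real shift. The reading of compound 2 is a limit of the assay, so the true size of the step stays unknown and only its floor can be stated: the limit of > 100000 nM in this assay, at which 2 of the 3 values shown sit.

The exchange swaps sulfur for oxygen and adds a six-membered aromatic ring in one step, and furan-2-yl on the same carbon would be needed to tell these two changes apart. Open too, on these data alone, is what an amine or a carboxylic acid at this place would do to the number.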